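A Carboxy-Bearing Aryl Group on the Shared Core

The source may hold more compounds than are shown below. What is called first, only, known or untested is meant among the compounds shown, and "the series" means these compounds.

In a functional assay on HeLa cells (Homo sapiens) for antiproliferative activity, read by MTT assay, with a stated time of 48 h (a higher number here means a weaker inhibitor, a lower number a stronger inhibitor), compound 1 (`COc1ccc(-c2cc3c(cn2)[nH]c(=O)n3-c2cc(OC)c(OC)c(OC)c2)cn1`) gives 870 nM, while compound 2 (`CCOc1ccc(-c2cc3c(cn2)[nH]c(=O)n3-c2cc(OC)c(OC)c(OC)c2)cc1F`) gives 2870 nM, the higher and thus weaker of the two numbers. Compound 3 (`COc1ccc(-c2cc3c(cn2)[nH]c(=O)n3-c2cc(OC)c(OC)c(OC)c2)cc1C(=O)O`) keeps the shared core but carries 3-carboxy-4-methoxyphenyl in place of 4-ethoxy-3-fluorophenyl on an aromatic carbon. Within the data shown here, only one measured step bears on this change, the modest aryl exchange a 3.3-fold higher number from compound 1 to compound 2 (0.52 log units; beyond the scatter). Among the measured compounds shown here, no measured compound carries a carboxy group, so the data give little guidance on direction. A step of similar modest size towards a higher number, meaning a weaker inhibitor, is nevertheless expected in this assay; the estimated step is a 1.9-fold higher number from compound 2 to compound 3 (0.28 log units; within the scatter). For compound 3 the estimated value is 5500 nM, with an expected range from 1800 nM to 17000 nM.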

Compound 3, half-maximal inhibitory concentration: 5990 nM
For compound 3 the middle estimate is 1.1-fold (0.04 log units) below the measured one; low and high end bracket the measured number.
By their numbers in this assay, from the lowest: compound 1; then compound 2; then compound 3.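

In this assay the exchange of 4-ethoxy-3-fluorophenyl for 3-carboxy-4-methoxyphenyl brings a 2.1-fold higher number from compound 2 to compound 3 (0.32 log units; beyond the scatter) and so extends the range of aryl groups read at this aromatic carbon of the shared core. Measured against the 6-methoxypyridin-3-yl group, the carboxy-bearing aryl group brings a 6.9-fold higher number from compound 1 to compound 3 (0.84 log units; beyond the scatter) and this is the largest step among the three compounds, with compound 1 still the strongest inhibitor of them. No measurement on hand offers an explanation for this order.

The compounds shown leave open whether the change follows from the carboxylic acid itself or from its pairing with the methoxy group on the same ring. They also do not tell how a methyl ester, a primary amide or an amine would read in place of that carboxylic acid, or how a carboxylic acid would read on the 6-methoxypyridin-3-yl ring.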